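The source may hold more compounds than are shown below. What is called first, only, known or untested is meant among the compounds shown, and "the series" means these compounds.

Compound 1 `Nc1nc(SCc2ccccc2)nc2c1nc(O)n2Cc1ccccc1`: 0.1 uM in a functional assay (spleen, spleen) for activation, with Mus musculus as the target; on this read-out lower numbers stand for an effect already at smaller amounts and higher numbers for an effect only at larger amounts of compound
Compound 2 `Nc1ncnc2c1nc(O)n2Cc1ccc(F)cc1`: 10 uM in this assay

Of the compounds shown here, two have been measured. Compound 1 gives 0.1 uM, the lowest of the two numbers; compound 2 gives 10 uM, a gap that lies beyond the usual scatter. Compound 3 `CCCCc1nc(N)c2nc(O)n(Cc3ccccc3)c2n1` has not yet been measured. It differs from compound 1 in one place: butyl in place of benzylsulfanyl on an aromatic carbon. For the measured compounds named here, no step between measured compounds that share exactly this change is available, so the expectation rests on the two values alone. Compound 2, which carries no group at that place, sits far above compound 1, and a butyl group keeps some of what is lost. The step from compound 1 is expected to be modest and upward, a 3.0-fold higher number from compound 1 to compound 3 (0.48 log units; beyond the scatter). Compound 3 is therefore estimated at 0.3 uM, within a range from 0.03 uM to 3 uM.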

Compound 3, minimum effective concentration: 0.03 uM
For compound 3 the middle estimate is 10-fold (1.00 log units) above the measured one; the range from low to high includes it.
By their numbers in this assay, from the lowest: compound 3; then compound 1; then compound 2.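

In this assay, butyl in place of benzylsulfanyl on the aromatic carbon between two ring nitrogen atoms gives a 3.3-fold lower number from compound 1 to compound 3 (0.52 log units; beyond the scatter) and so moves the number down rather than up. This pair shows that neither the sulfur nor the six-membered aromatic ring of benzylsulfanyl is needed at this place for a low number on the core of compound 1, since a plain chain with no ring does better there. Nothing shown gives a reason for this step. 

From the compounds shown here alone, with a single pair at this place, it remains open whether the gain belongs to losing the sulfur or to losing the ring, a question that a butylsulfanyl group would address. Going by these compounds, it is equally open how a shorter or longer alkyl chain, an alkoxy group or an amine would fare on the same core.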